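Notes on solubility across compounds 1 to 4

The compounds below may be only part of what the source reports. "The series", "measured", "known", "first", "only" and "open" are said of these compounds alone.

Measured compounds in a physicochemical assay for solubility, read by spectrophotometry, in phosphate buffer, with a stated time of 2 h, at pH 7.4; a higher number here means a more soluble compound, a lower number a less soluble compound:
- compound 1 `COc1ccc2[nH]c(C(=O)N3CC(=O)N(Cc4ccccc4)[C@@H](CCc4ccccc4)C3)cc2c1`: 4400 nM
- compound 2 `COc1ccc2[nH]c(C(=O)N3CC(=O)N(Cc4ccccc4)[C@@H](COc4ccccc4)C3)cc2c1`: 12200 nM
- compound 3 `COc1ccc2[nH]c(C(=O)N3CC(=O)N(Cc4ccccc4)[C@@H](CN4CCC5(CC4)CC5)C3)cc2c1`: 28200 nM

Compound 1 gives the lowest number of the three in this assay; its nearest neighbour is compound 2, and compound 3 lies furthest from it. Both steps away from compound 1 are modest: a 2.8-fold higher number from compound 1 to compound 2 (0.44 log units; beyond the scatter) and a 6.4-fold higher number from compound 1 to compound 3 (0.81 log units; beyond the scatter); between the other two, a 2.3-fold higher number from compound 2 to compound 3 (0.36 log units; beyond the scatter).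

Compound 4 `COc1ccc2[nH]c(C(=O)N3CC(=O)N(Cc4ccccc4)[C@@H](COCc4ccccc4)C3)cc2c1` differs from compound 1 as follows: benzyloxy in place of benzyl on a saturated chain carbon bound to a saturated ring carbon. Among the compounds with values here, the most pertinent measured step is the one from compound 1 to compound 2, where phenoxy replaced benzyl on the same saturated chain carbon and an oxygen likewise entered; that step was modest and upward. The step from compound 1 to compound 3 also ran upward but swaps in a quite different group and is a weaker guide. A modest rise in this assay is therefore expected, a 2.0-fold higher number from compound 1 to compound 4 (0.31 log units; beyond the scatter), with a result for compound 4 estimated at 9000 nM (range 4000 nM to 20000 nM).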

Compound 4, solubility: 8800 nM
The estimate for compound 4 lay 1.0-fold (0.01 log units) above the measured number; low and high end bracket the measured number.
By their numbers in this assay, from the lowest: compounds 1, 4 and 2 (each within the scatter of the next, the first and the last beyond it); then compound 3.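

In this assay, benzyloxy in place of benzyl on a saturated chain carbon bound to a saturated ring carbon gives a 2.0-fold higher number from compound 1 to compound 4 (0.30 log units; within the scatter) and so cannot be told apart from compound 1, although the phenoxy step from the same starting point lay beyond the scatter. The comparison of the two ethers gives a 1.4-fold lower number from compound 2 to compound 4 (0.14 log units; within the scatter) and does not separate them, so compound 4 sits within the scatter of both compound 1 and compound 2. Only the group in compound 3 stands clearly apart from benzyloxy at this position, with a 3.2-fold lower number from compound 3 to compound 4 (0.51 log units; beyond the scatter) as the step.

From the compounds shown here alone, whether a carboxylic acid or a hydroxyl group on this saturated chain carbon would reach the level of compound 3 at 28200 nM remains open. No supporting data bear on the reason for these differences.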